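Phenoxy in Place of Ethylphenyl: An Expected Return

The source may report more compounds than this note shows. Statements on the series, on what has been measured and on what is new or still open speak of the compounds shown alone.

Three compounds sharing one core have been measured in a functional assay on BXPC-3 cells (Homo sapiens) for cytotoxicity, read by MTT assay, with a stated time of 72 h; on this read-out lower numbers stand for stronger inhibition and higher numbers for weaker inhibition:

compound 1, `O=C1C(Nc2ccc(OC(F)(F)F)cc2)=CC(=O)c2ncncc21`: 900 nM
compound 2, `O=C1C(Nc2ccc(-c3ccccc3)cc2)=CC(=O)c2ncncc21`: 500 nM
compound 3, `CCc1ccc(-c2ccc(NC3=CC(=O)c4ncncc4C3=O)cc2)cc1`: 3100 nM

Compound 3 stands at the highest number of the three, and both of its steps lie beyond the scatter: a 3.4-fold higher number from compound 1 to compound 3 (0.54 log units; beyond the scatter) and a 6.2-fold higher number from compound 2 to compound 3 (0.79 log units; beyond the scatter). The remaining pair is closer, since a 1.8-fold lower number from compound 1 to compound 2 (0.26 log units; within the scatter).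

Compound 4, `O=C1C(Nc2ccc(Oc3ccccc3)cc2)=CC(=O)c2ncncc21`, has not yet been measured in this assay. Its change from compound 3 is phenoxy in place of 4-ethylphenyl on an aromatic carbon.

Among the compounds with values here, two measured steps bear on this change. The step from compound 2 to compound 3 shows that the ethyl on the outer ring alone carried the rise to the highest number, so removing it should give much of that back. The step from compound 1 to compound 2 shows that a trifluoromethoxy and a phenyl on the same carbon give numbers within the scatter of each other, and phenoxy shares the oxygen of the one and the aromatic ring of the other. A clearly lower number than compound 3 is therefore expected, landing near compounds 1 and 2. Compound 4 is expected to give about 700 nM, within a range from 250 nM to 2000 nM. That estimate means an expected step of a 4.4-fold lower number from compound 3 to compound 4 (0.65 log units; beyond the scatter).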

Compound 4, half-maximal inhibitory concentration: 3600 nM
Compound 4: middle estimate off by 5.1-fold (0.71 log units), on the low side; measured number outside the range, above it.
By their numbers in this assay, from the lowest: compounds 2 and 1 (each within the scatter of the next); then compounds 3 and 4 (each within the scatter of the next).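

In this assay, phenoxy and 4-ethylphenyl on this aromatic carbon, para to a large group, give numbers that cannot be told apart (a 1.2-fold higher number from compound 3 to compound 4 (0.06 log units; within the scatter)), so a high number at this position does not depend on the ethyl-bearing outer ring alone. Phenoxy instead separates clearly from the two groups that gave the low numbers, with a 7.2-fold higher number from compound 2 to compound 4 (0.86 log units; beyond the scatter) when the oxygen is added to the link to the outer ring and a 4.0-fold higher number from compound 1 to compound 4 (0.60 log units; beyond the scatter) when phenyl replaces trifluoromethyl on that oxygen, which shows that sharing an oxygen with one group and an aromatic ring with the other did not place phenoxy with either. No measurement offered here accounts for why phenoxy and 4-ethylphenyl fall together. On these data alone, it remains open whether benzyl, with a carbon in the link, or anilino, with an amine in the link, would sit with compounds 1 and 2 or with compounds 3 and 4. Also open, as far as these compounds go, is whether a smaller group on the same oxygen, such as methoxy, would stay with compound 1, or whether a methyl on the outer ring of compound 2 would already move the number as ethyl does.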